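The source may hold more compounds than are shown below. What is called first, only, known or untested is meant among the compounds shown, and "the series" means these compounds.

Of the compounds shown here, three built on one shared core have been measured in a physicochemical assay for lipophilicity, measured as octanol-water partition; on this read-out higher numbers stand for higher lipophilicity and lower numbers for lower lipophilicity. Compound 1 `O=C(COc1cccc2ccccc12)N/N=C/c1ccc(Cl)cc1` gives 4.54, compound 2 `O=C(COc1cccc2ccccc12)N/N=C/c1ccccc1Br` gives 4.81 and compound 3 `O=C(COc1cccc2ccccc12)N/N=C/C=C/c1ccccc1` gives 4.43. On these numbers compound 1 sits between the other two, yet both gaps stay within the scatter: a number 0.27 log units higher from compound 1 to compound 2 (within the scatter) and a number 0.11 log units lower from compound 1 to compound 3 (within the scatter). Going by the values given here, only the step of a number 0.38 log units lower from compound 2 to compound 3 (beyond the scatter) exceeds it. Compound 4 `O=C(COc1cccc2ccccc12)N/N=C/c1ccc([N+](=O)[O-])cc1` differs from compound 1 by nitro in place of chloro on an aromatic carbon. Among the compounds with values here, none of the measured steps swaps chloro for nitro; each exchanges the entire group on the carbon double-bonded to nitrogen, so they offer no direct guide. Drawing on common experience with such a swap, compound 4 is expected to show a number 0.99 log units lower from compound 1 to compound 4 (beyond the scatter) in this assay, an estimate of 3.55, likely between 3.1 and 4.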

Compound 4, partition coefficient: 3.97
For compound 4 the middle estimate is 0.42 log units below the measured one; the range from low to high includes it.
By their numbers in this assay, from the lowest: compound 4; then compounds 3, 1 and 2 (each within the scatter of the next, the first and the last beyond it).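

In this assay, going by these compounds alone, nitro in place of chloro on an aromatic carbon gives a number 0.57 log units lower from compound 1 to compound 4 (beyond the scatter) and is the first step here confined to one substituent, not the whole group on the carbon with a double bond to nitrogen. This place, para to a large group, is therefore one where a single swap can move the number beyond the scatter.

As far as these compounds go, whether an amine or a carboxylic acid at the same place would give a similar step remains open. No measurement shown here explains this step.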